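The source may report more compounds than this note shows. Statements on the series, on what has been measured and on what is new or still open speak of the compounds shown alone.

Compound 1, `CCCCc1ccc(-c2cc(Cl)cc(C(=O)Nc3nn[nH]n3)n2)cc1`: 83%
Compound 2, `CCCCc1ccc(-c2cc(OC)cc(C(=O)Nc3nn[nH]n3)n2)cc1`: 61%
Compound 3, `COc1ccc(-c2cc(C)cc(C(=O)Nc3nn[nH]n3)n2)cc1`: 43%

In a functional assay on the whole organism with Rattus norvegicus as the target, at a dose of 3 mg/kg by the oral route (on this read-out lower numbers stand for a weaker effect and higher numbers for a stronger effect at the one dose given), compound 3 stands lowest of the three measured numbers, beyond the scatter below compound 2 and furthest from compound 1. Compound 4, `CCCCc1ccc(-c2cc(C)cc(C(=O)Nc3nn[nH]n3)n2)cc1`, has not yet been measured. Its difference from compound 3 is butyl in place of methoxy on an aromatic carbon. Within the data shown here, the one measured step, a number 22 percentage points lower from compound 1 to compound 2 (beyond the scatter), concerns the group on the other ring and so does not bear on this change. Among the measured compounds shown here, no measured pair isolates the exchange of methoxy for butyl; compound 1 and compound 2, which both carry butyl, give higher numbers than compound 3, but each also differs from it elsewhere. A modest rise, a number 17 percentage points higher from compound 3 to compound 4 (beyond the scatter), is therefore expected. Compound 4 is estimated at 60%, between 40% and 80%.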

Compound 4, a percentage reported as inhibition, in the whole organism at one dose (the size of the read-out at that dose, not a potency): 67%
The estimate for compound 4 lay 7 percentage points below the measured number, and the stated range covers the measured number.
By their numbers in this assay, from the lowest: compound 3; then compounds 2 and 4 (each within the scatter of the next); then compound 1.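

In this assay, among these compounds, butyl in place of methoxy, on the aromatic carbon para to a large group, gives a number 24 percentage points higher from compound 3 to compound 4 (beyond the scatter) and is the first pair to isolate this exchange. At the other changing position, methyl in place of methoxy gives a number 6 percentage points higher from compound 2 to compound 4 (within the scatter) and so does not separate the two groups, whereas methyl in place of chloro gives a number 16 percentage points lower from compound 1 to compound 4 (beyond the scatter) and leaves chloro with the higher number. Nothing available explains these differences. Going by these compounds, it remains open whether a longer chain such as hexyl, or an amine, would keep the number at the butyl carbon.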